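The compounds below may be only part of what the source reports. "The series", "measured", "known", "first", "only" and "open" are said of these compounds alone.

Compound 1 `O=C(COCc1ccncn1)N1CCN(c2ccc(Cl)cc2Cl)CC1`: 2800 nM
Compound 2 `O=C(COCc1cccs1)N1CCN(c2ccc(Cl)cc2Cl)CC1`: > 310 nM

In a functional assay on HEK293 cells for positive allosteric modulation of metabotropic glutamate receptor 5 (Homo sapiens), read by FLIPR and calcium flux (a higher number here means that more compound is needed for the effect, a lower number that less compound is needed), compound 1 gives 2800 nM. For compound 2 the read-out is only a limit, > 310 nM, so its place on the scale is bounded on one side and not fixed. This is the line (the limit of > 310 nM in this assay, at which 1 of the 2 values shown sits), and it leaves the step that the limit leaves unreadable from compound 1 to compound 2 without a readable size. Compound 3 `O=C(CCCc1ccncc1)N1CCN(c2ccc(Cl)cc2Cl)CC1` is not yet measured. It differs from compound 2 by 2-(pyridin-4-yl)ethyl in place of (thiophen-2-yl)methoxy on a saturated chain carbon bound to a carbonyl carbon. Among the measured compounds shown here, the single measured step, that from compound 1 to compound 2, is the only one that could guide this change, and it cannot be read, so neither a size nor a direction can be carried over. The expectation for compound 3 is a weak effect, with the expected step that the limit leaves unreadable from compound 2 to compound 3 staying close to the region of the limit. Compound 3 is estimated at 4000 nM, with a range from 800 nM to 20000 nM, and the assay may well report only a limit again.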

Compound 3, half-maximal effective concentration: 5300 nM
Beside the measured number, compound 3's estimate is 1.3-fold (0.12 log units) below it; the range from low to high includes it.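

In this assay there is a 1.9-fold higher number from compound 1 to compound 3 (0.28 log units; within the scatter). Among the compounds shown here, this is the first readable step at this position: 2-(pyridin-4-yl)ethyl in place of (pyrimidin-4-yl)methoxy on a saturated chain carbon bound to a carbonyl carbon leaves the two compounds within the usual scatter of each other, so this exchange of ring and linking chain together gives no measurable difference. Compound 2 has only a limit, > 310 nM, and the steps that involve it cannot be read: the limit of > 310 nM in this assay, at which 1 of the 3 values shown sits.

Because the ring and the linking chain change together, the step does not show what each contributes alone, and a (pyridin-4-yl)methoxy group would separate the two. As far as these compounds go, it also remains open whether a plain phenyl ring or a longer chain at this place would shift the read-out beyond the scatter.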